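A few compounds are considered here, and "the series" means these few. Any claim that something is new, unique, unknown or untested is made for them only; others in the source may bear on it.

Measured so far in a functional assay on BaF3 cells (Mus musculus) for antiproliferative activity, read by CCK-8 assay and cell counting, with a stated time of 76 h; a lower number here means a stronger inhibitor, a higher number a weaker inhibitor:
Compound 1 `COc1cc2nccc(Oc3ccc(Nc4nn(C)cc4C(=O)NOCc4ccccc4)cc3)c2cc1C(N)=O` gives a limit of the assay, > 10000 nM, not a number.
Compound 2 `COc1cc2nccc(Oc3ccc(Nc4nn(C)cc4C(=O)Nc4cccc(F)c4)cc3)c2cc1C(N)=O` gives 4480 nM.
Compound 3 `COc1cc2nccc(Oc3ccc(Nc4nn(C)cc4C(=O)N4CCCC5CCCCC54)cc3)c2cc1C(N)=O` gives 4330 nM.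

Among the two numbers, compound 2 stands highest; its nearest neighbour is compound 3, and the gap between them, a 1.0-fold lower number from compound 2 to compound 3 (0.01 log units; within the scatter), is within the scatter, so the two cannot be told apart. The unmeasured compound 4 `COc1cc2nccc(Oc3ccc(Nc4nn(C)cc4C(=O)NC4CCCC4)cc3)c2cc1C(N)=O` differs from compound 2 at the amide-type nitrogen: cyclopentyl in place of 3-fluorophenyl on an amide-type nitrogen. Among the measured compounds shown here, two measured steps bear on this position. Going from the benzyloxy group to the 3-fluorophenyl group gave an at least 2.2-fold lower number from compound 1 to compound 2 (0.34 log units; beyond the scatter), which starts from a limit of > 10000 nM in this assay, at which 1 of the 3 values shown sits, and so only sets a floor on that step. Exchanging the 3-fluorophenyl amide for the larger saturated bicyclic amine gave a 1.0-fold lower number from compound 2 to compound 3 (0.01 log units; within the scatter), which is within the scatter. A non-aromatic ring on this nitrogen therefore seems tolerated without clear gain or loss, and for compound 4 the expected step is a 1.0-fold higher number from compound 2 to compound 4 (0.00 log units; within the scatter), within the scatter. Compound 4 is estimated at 4500 nM, with a range from 1500 nM to 13000 nM.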

Compound 4, half-maximal inhibitory concentration: > 10000 nM
Compound 4 ended at the assay's limit (the forecaster's own chance of this, stated with the estimate: 20%); middle value at least 2.2-fold (0.34 log units) from the limit.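

In this assay compound 4 gives > 10000 nM, which is a limit of the assay and not a number. Cyclopentyl on this amide-type nitrogen gives an at least 2.2-fold higher number from compound 2 to compound 4 (0.34 log units; beyond the scatter), and the comparison with the saturated bicyclic amide gives an at least 2.3-fold higher number from compound 3 to compound 4 (0.36 log units; beyond the scatter); both steps are floors, and both lie beyond the scatter. Compound 3 alone had suggested that a non-aromatic ring is tolerated here, but compound 4 shows that such a ring does not by itself keep the level of compound 2 and compound 3, and a second compound now sits at the limit: the limit of > 10000 nM in this assay, at which 2 of the 4 values shown sit.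

The step between compound 1 and compound 4 cannot be read, as both values are limits. Still open, going by these compounds, is how a plain phenyl or a cyclohexyl group on this nitrogen would compare with 3-fluorophenyl and cyclopentyl.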